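Compound 3 After Two Cell-Growth Limits

This account rests on a few compounds, and the source may have more. Where it says the series, first, only, none or still open, it means among the compounds named here.

Compound 1, `CC1=CC[C@@H]([C@@](C)(O)CCCC(C)(C)NC(=S)N/N=C\c2ccc(C)cc2)CC1`, in a functional assay on NCI-H460 cells (Homo sapiens) for cytotoxicity, read by sulforhodamine B assay (on this read-out lower numbers stand for stronger inhibition of growth and higher numbers for weaker inhibition of growth), gives > 100000 nM, a limit of the assay.
Compound 2, `CC1=CC[C@@H]([C@@](C)(O)CCCC(C)(C)NC(=S)N/N=C\c2ccc([N+](=O)[O-])cc2)CC1`, in this assay gives > 100000 nM, again a limit of the assay.

Compound 2 therefore stands at the limit of > 100000 nM in this assay, at which 2 of the 2 values shown sit, and no number is known for it. Within the data shown here, the one measured step, a step that the two limits leave unreadable from compound 1 to compound 2, is the change of nitro in place of methyl on an aromatic carbon; its size cannot be read, since both ends are limits. Compound 3, `CC1=CC[C@@H]([C@@](C)(O)CCCC(C)(C)NC(=S)N/N=C\c2ccccc2Cl)CC1`, differs from compound 2 by 2-chlorophenyl in place of 4-nitrophenyl on a carbon with a double bond to nitrogen. Among the measured compounds shown here, no measured step bears on this change, and the two limits give no direction, so no step of readable size is expected in this assay. Compound 3 is expected at 150000 nM, within 20000 nM to 1000000 nM, most likely again as a limit. The step from compound 2 to compound 3 that this estimate means is a step that the limit leaves unreadable from compound 2 to compound 3.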

Compound 3, concentration for total growth inhibition: > 100000 nM
Compound 3 gave a limit, no number; the forecaster's own chance of this, stated with the estimate: 75%; the middle value is on the limit's open side.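

Compound 3, like compound 1 and compound 2, sits at a limit of this assay, so no step among these compounds can be read: the limit of > 100000 nM in this assay, at which 3 of the 3 values shown sit.

The compounds shown leave open whether any group on the carbon with a double bond to nitrogen would give a readable number for growth inhibition.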